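The compounds below may be only part of what the source reports. "The series", "measured", "known", "first", "only" and "open" are said of these compounds alone.

Measured so far in a physicochemical assay for lipophilicity, at pH 7.4; a lower number here means a more polar compound, a higher number a more lipophilic compound:
compound 1 `CN(Cc1ccc2nccn2c1)c1nnc(-c2ccc(-c3ccccc3)cc2)o1`: 3.9
compound 2 `COc1ccccc1-c1ccc(-c2nnc(N(C)Cc3ccc4nccn4c3)o2)cc1`: 4.1
compound 3 `CN(Cc1ccc2nccn2c1)c1nnc(-c2ccc(-c3ccccc3C#N)cc2)o1`: 3.6

Compound 3 has the lowest of the three numbers in this assay; compound 1 is its nearest neighbour and compound 2 its furthest. Compound 4 `Cc1ccccc1-c1ccc(-c2nnc(N(C)Cc3ccc4nccn4c3)o2)cc1` differs from compound 3 by methyl in place of cyano on an aromatic carbon, on an aromatic carbon of a six-membered aromatic ring of carbon only. Going by the values given here, two measured steps bear on this change: cyano entering for hydrogen gave a number 0.30 log units lower from compound 1 to compound 3 (within the scatter), and cyano entering for methoxy gave a number 0.50 log units lower from compound 2 to compound 3 (beyond the scatter). Taking the cyano out again is expected to undo roughly the first step, and the second step points the same way, so for compound 4 a modest rise is expected, a number 0.70 log units higher from compound 3 to compound 4 (beyond the scatter). Compound 4 is accordingly estimated at 4.3, with a range from 3.9 to 4.7.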

Compound 4, distribution coefficient: 4.7
Compound 4: the middle estimate sits 0.40 log units below what was measured, within the range that was stated.
By their numbers in this assay, from the lowest: compounds 3, 1 and 2 (each within the scatter of the next, the first and the last beyond it); then compound 4.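

In this assay, methyl at this place, ortho to a large group, gives the largest step in the set (a number 1.10 log units higher from compound 3 to compound 4 (beyond the scatter)). It also clears the scatter against hydrogen (a number 0.80 log units higher from compound 1 to compound 4 (beyond the scatter)) and methoxy (a number 0.60 log units higher from compound 2 to compound 4 (beyond the scatter)), so compound 4 holds the highest number of the four and stands apart from all the other groups shown here. No measurement at hand accounts for the size of these steps.

As far as these compounds go, whether an ethyl group or a longer chain would extend the rise remains open. So does the effect of an amine or a carboxylic acid at this place.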